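Fluoro to methyl replacement in a three-compound set

The source may report more compounds than this note shows. Statements on the series, on what has been measured and on what is new or still open speak of the compounds shown alone.

Measured so far in a functional assay on MCF7 cells (Homo sapiens) for antiproliferative activity, read by MTT assay, with a stated time of 48 h; on this read-out lower numbers stand for stronger inhibition and higher numbers for weaker inhibition:
compound 1 `Cc1cnc(Nc2ccc(S(C)(=O)=O)cc2)nc1Nc1nc2ccc(Cl)cc2s1` gives 4320 nM
compound 2 `CS(=O)(=O)c1ccc(Nc2ncc(F)c(Nc3nc4ccc(Cl)cc4s3)n2)cc1` gives > 50000 nM, a limit of the assay and not a number the limit of > 50000 nM in this assay, at which 1 of the 3 values shown sits.
compound 3 `NS(=O)(=O)c1ccc(Nc2nccc(Nc3nc4ccc(F)cc4s3)n2)cc1` gives 10900 nM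

Compound 1 and compound 2 share a core and differ in one place only: methyl in place of fluoro on an aromatic carbon. The step is an at least 11-fold lower number from compound 2 to compound 1 (1.06 log units; beyond the scatter); since compound 2 sits at the limit (the limit of > 50000 nM in this assay, at which 1 of the 3 values shown sits), the true size of this step is not bounded from above. Compound 3 gives a higher number than compound 1 in this assay, the gap being beyond the scatter. The difference between the cores of compound 2 and compound 3 is not broken down here.

Compound 4 `Cc1ccc2nc(Nc3ccnc(Nc4ccc(S(N)(=O)=O)cc4)n3)sc2c1` is not yet measured. Relative to compound 3 it carries methyl in place of fluoro on an aromatic carbon. This is the same kind of change as that from compound 2 to compound 1, but not the same: there the methyl entered on a six-membered aromatic ring with 2 nitrogen, ortho to a large group, two atoms from the ring nitrogen and para to a large group, whereas here it enters on a six-membered aromatic ring of carbon only, part of a fused system of two rings, meta to a fused ring and para to a fused ring. The measured step is therefore only a loose guide. A gain is expected from compound 3 to compound 4, but a smaller one than an at least 11-fold lower number from compound 2 to compound 1 (1.06 log units; beyond the scatter), because that step rests on a limit of > 50000 nM in this assay, at which 1 of the 3 values shown sits, and on a different place; the expected step is a 1.8-fold lower number from compound 3 to compound 4 (0.26 log units; within the scatter). For compound 4 in this assay the estimate is 6000 nM, with a likely range from 2000 nM to 25000 nM.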

Compound 4, half-maximal inhibitory concentration: 5740 nM
Beside the measured number, compound 4's estimate is 1.0-fold (0.02 log units) above it; low and high end bracket the measured number.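

In this assay, methyl in place of fluoro on an aromatic carbon gives a 1.9-fold lower number from compound 3 to compound 4 (0.28 log units; within the scatter), so on the core of compound 3 this replacement cannot be told apart from the ordinary spread of repeat measurements. The replacement therefore does not carry over from one core to the other at a single size: the same change on two cores in this assay, an at least 11-fold lower number (1.06 log units; beyond the scatter) from compound 2 to compound 1 and a 1.9-fold lower number (0.28 log units; within the scatter) from compound 3 to compound 4, at least 6.0-fold (0.78 log units) apart, beyond the scatter of two such steps Compound 2 gives a limit of the assay and not a number, which leaves the earlier step without an upper bound, and these two pairs alone cannot show whether the gap follows the rest of the core or the ring that carries the methyl: the limit of > 50000 nM in this assay, at which 1 of the 4 values shown sits.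

The compounds shown leave open how a methoxy group, a nitrile or an amine would behave in place of fluoro or methyl on either ring, as each position is represented here only by that one replacement. Also open is how the methylsulfonyl group of compounds 1 and 2 compares with the sulfonamide of compounds 3 and 4 on an otherwise unchanged structure, a comparison that none of the pairs shown isolates.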